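A few compounds are considered here, and "the series" means these few. Any claim that something is new, unique, unknown or untested is made for them only; others in the source may bear on it.

In a functional assay on HT-29 cells (Homo sapiens) for cytotoxicity, read by MTT assay, with a stated time of 72 h (on this read-out higher numbers stand for weaker inhibition and lower numbers for stronger inhibition), two compounds sharing one core have been measured so far. Compound 1 (`Cc1ccc(F)cc1NC(=O)CN1CCN(c2nnc(Cc3ccccc3)c3ccccc23)CC1`) gives 171000 nM, and compound 2 (`Cc1ccccc1NC(=O)CN1CCN(c2nnc(Cc3ccccc3)c3ccccc23)CC1`) gives 113000 nM. For the measured compounds named here, compound 2 therefore stands level with its only measured neighbour, and both numbers are of the same high order. The next compound to be tested is compound 3 (`Cc1cccc(Cl)c1NC(=O)CN1CCN(c2nnc(Cc3ccccc3)c3ccccc23)CC1`). It differs from compound 2 by chloro in place of hydrogen on an aromatic carbon, ortho to a large group and meta to a methyl group. Going by the values given here, only one measured step bears on this change, the replacement of fluoro by hydrogen on an aromatic carbon, which gives a 1.5-fold lower number from compound 1 to compound 2 (0.18 log units; within the scatter). Among the compounds with values here, that step concerns fluoro rather than chloro, so it is only a loose guide, and no measurement yet shows what chloro does. A shift beyond the scatter is therefore not expected in this assay, and no firm direction can be assigned. The expected change is a 1.2-fold higher number from compound 2 to compound 3 (0.06 log units; within the scatter). For compound 3 the estimated value is 130000 nM, with an expected range from 60000 nM to 280000 nM.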

Compound 3, half-maximal inhibitory concentration: 53600 nM
Beside the measured number, compound 3's estimate is 2.4-fold (0.38 log units) above it, and the stated range ends above it.
By their numbers in this assay, from the lowest: compound 3; then compounds 2 and 1 (each within the scatter of the next).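

In this assay, for the compounds shown here, chloro in place of hydrogen on an aromatic carbon, ortho to a large group and meta to a methyl group, gives a 2.1-fold lower number from compound 2 to compound 3 (0.32 log units; beyond the scatter), the first step to lie beyond the scatter, although it is a modest one. Read as a change of the whole aromatic group, 2-chloro-6-methylphenyl in place of 5-fluoro-2-methylphenyl on an amide-type nitrogen gives a 3.2-fold lower number from compound 1 to compound 3 (0.50 log units; beyond the scatter), also modest, so compound 3 is the only one of the three set apart from both others beyond the scatter. Nothing measured here explains why this position responds to chloro.

The compounds shown leave open whether bromo, methoxy or an amine on the same aromatic carbon would move the number as chloro does, and whether the chloro step would hold if the methyl group were replaced by hydrogen. They also leave open how much lower the number can go, since all three values remain of the same high order.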